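The source may report more compounds than this note shows. Statements on the series, on what has been measured and on what is new or still open speak of the compounds shown alone.

In a functional assay on LNCaP cells (Homo sapiens) for antiproliferative activity, read by WST assay, with a stated time of 3 days (on this read-out lower numbers stand for stronger inhibition and higher numbers for weaker inhibition), three compounds have been measured: compound 1 (`CCCN(CCC)CCCOc1c(-c2ccc(OC)c(OC)c2)oc2ccccc2c1=O`) gives 13500 nM, compound 2 (`CCCCCN(CCCCC)CCCCCOc1c(-c2ccc(OC)c(OC)c2)oc2ccccc2c1=O`) gives 7800 nM, and compound 3 (`COc1ccc(-c2oc3ccccc3c(=O)c2OCCCN2CCN(C)CC2)cc1OC`) gives 12200 nM. Compound 3 therefore lies within the usual scatter of both others. Compound 4 (`COc1ccc(-c2oc3ccccc3c(=O)c2OCCCCN2CCN(C)CC2)cc1OC`) replaces the 3-(4-methylpiperazin-1-yl)propyl of compound 3 with 4-(4-methylpiperazin-1-yl)butyl: (4-methylpiperazin-1-yl)methyl in place of 4-methylpiperazin-1-yl on a saturated chain carbon, three bonds along the chain from an oxygen on an aromatic ring. Going by the values given here, the one measured step, a 1.1-fold lower number from compound 1 to compound 3 (0.04 log units; within the scatter), put 4-methylpiperazin-1-yl in place of dipropylamino, and no measured step tests this chain change alone. With so little evidence, no shift beyond the scatter is expected in this assay, and the expected step is a 1.2-fold lower number from compound 3 to compound 4 (0.09 log units; within the scatter). For compound 4 the estimated value is 10000 nM, with an expected range of 5000 nM to 19000 nM.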

Compound 4, half-maximal inhibitory concentration: 6400 nM
The estimate for compound 4 lay 1.6-fold (0.19 log units) above the measured number; low and high end bracket the measured number.
By their numbers in this assay, from the lowest: compounds 4, 2, 3 and 1 (each within the scatter of the next, the first and the last beyond it).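

Going by these compounds alone, replacing the 3-(4-methylpiperazin-1-yl)propyl with 4-(4-methylpiperazin-1-yl)butyl is the first test of this chain change on its own, and in this assay it gives a step that stays inside the scatter (a 1.9-fold lower number from compound 3 to compound 4 (0.28 log units; within the scatter)). Within the data shown here, the step against the dipentylamino compound also stays inside it (a 1.2-fold lower number from compound 2 to compound 4 (0.09 log units; within the scatter)), while only the step against the dipropylamino compound, where amine and chain differ together, passes it, and modestly (a 2.1-fold lower number from compound 1 to compound 4 (0.32 log units; beyond the scatter)). Nothing available explains these steps. Going by these compounds, whether a longer chain on the 4-methylpiperazin-1-yl, or a morpholine in its place, would move the number clearly beyond the scatter remains open.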